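Chain-end aryl swap: trifluorophenyl for fluoromethylphenyl

A few compounds are considered here, and "the series" means these few. Any claim that something is new, unique, unknown or untested is made for them only; others in the source may bear on it.

Measured compounds:
compound 1 `Cc1c(F)cccc1CCCCOc1ccc(/C=C/c2cccc3c(CCCC(=O)O)c(C)n(CC(=O)O)c23)cc1` — 83%
compound 2 `Cc1c(F)cccc1CCCCOc1ccc(/C=C/c2cccc3c(CCCC(=O)O)cn(CC(=O)O)c23)cc1` — 73%
compound 3 `Cc1c(Cl)cccc1CCCCOc1ccc(C#Cc2ccc(F)c3c(CCCC(=O)O)c(C)n(CCCC(=O)O)c23)cc1` — 99%

In a functional assay on the whole organism for inhibition, with Cavia porcellus as the target, with stated times of 1 h and 10 min, at a dose of 0.3 mg/kg by the oral route (a lower number here means a weaker effect, a higher number a stronger effect of the compound at the dose given), compound 2 gives 73%, the low end of the three numbers. Compound 1 gives 83% in this assay, and the step of a number 10 percentage points lower from compound 1 to compound 2 (within the scatter) lies within the scatter, so the two are not separated. Compound 3 gives 99% in this assay, beyond the scatter above compound 2, but compound 3 differs from compound 2 in several places at once and no single step can be read from that pair.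

Compound 4 `O=C(O)CCCc1cn(CC(=O)O)c2c(/C=C/c3ccc(OCCCCc4c(F)ccc(F)c4F)cc3)cccc12` has not been measured. Its difference from compound 2 is 2,3,6-trifluorophenyl in place of 3-fluoro-2-methylphenyl on a saturated chain carbon, four bonds along the chain from an oxygen on an aromatic ring. Among the compounds with values here, no measured step touches the aromatic ring at the end of the saturated chain; the only single step, from compound 1 to compound 2, sits on the shared core and was within the scatter. There is therefore nothing in hand to predict a shift at this position, and the expected step of a number 1 percentage points higher from compound 2 to compound 4 (within the scatter) is none beyond the scatter. Compound 4 is estimated to give 74% in this assay, with a range from 52% to 92%.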

Compound 4, a percentage reported as inhibition, in the whole organism at one dose (the size of the read-out at that dose, not a potency): 45%
Compound 4: the middle estimate sits 29 percentage points above what was measured; the whole stated range lies above it.
By their numbers in this assay, from the lowest: compound 4; then compounds 2 and 1 (each within the scatter of the next); then compound 3.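

The aryl group at the end of the saturated chain is not a silent position. Within the data shown here, putting 2,3,6-trifluorophenyl in place of 3-fluoro-2-methylphenyl gives a number 28 percentage points lower from compound 2 to compound 4 (beyond the scatter) in this assay and is the first single change to separate two compounds beyond the scatter, whereas the earlier step on the shared core, a number 10 percentage points lower from compound 1 to compound 2 (within the scatter), did not. No measurement in hand bears on the reason for this step.

This change removes the methyl and adds fluorines in one move, so the compounds shown cannot tell which part carries the step, and an unsubstituted phenyl or a 2-methylphenyl at the chain end would divide the two. Going by these compounds, whether the same swap costs as much on the core of compound 1 also remains open.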